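This account rests on a few compounds, and the source may have more. Where it says the series, first, only, none or still open, it means among the compounds named here.

In a functional assay on P388 cells (Mus musculus) for cytotoxicity (a lower number here means a stronger inhibitor, a higher number a weaker inhibitor), compound 1 `C=Cc1ccc(C[C@H]2C(=O)N[C@@H](C)C(=O)N(C)[C@H]3Cc4ccc(cc4)Oc4cc(ccc4OC)C[C@@H](C(=O)N[C@H](C)C(=O)N[C@@H](C)C(=O)N2C)N(C)C3=O)cc1` gives 17 nM, compound 3 `COc1ccc(C[C@H]2C(=O)N[C@@H](C)C(=O)N(C)[C@H]3Cc4ccc(cc4)Oc4cc(ccc4OC)C[C@@H](C(=O)N[C@H](C)C(=O)N[C@@H](C)C(=O)N2C)N(C)C3=O)cc1O` gives 214 nM, and compound 2 `COc1ccc(C[C@H]2C(=O)N[C@@H](C)C(=O)N(C)[C@H]3Cc4ccc(c(O)c4)Oc4cc(ccc4OC)C[C@@H](C(=O)N[C@H](C)C(=O)N[C@@H](C)C(=O)N2C)N(C)C3=O)cc1` gives 4790 nM; 5750 nM (2 entries). Compound 3 therefore stands well above compound 1 but below both entries of compound 2. Among the compounds with values here, the only measured step, a 13-fold higher number from compound 1 to compound 3 (1.10 log units; beyond the scatter), is large but concerns a different change. Compound 4 `COc1ccc(C[C@H]2C(=O)N[C@@H](C)C(=O)N(C)[C@H]3Cc4ccc(c(O)c4)Oc4cc(ccc4OC)C[C@@H](C(=O)N[C@H](C)C(=O)N[C@@H](C)C(=O)N2C)N(C)C3=O)cc1O` differs from compound 3 by hydroxy in place of hydrogen on an aromatic carbon. Compound 2, at 4790 nM; 5750 nM (2 entries), already carries this hydroxy, so a large upward step is expected in this assay. The expected change is a 28-fold higher number from compound 3 to compound 4 (1.45 log units; beyond the scatter). For compound 4 the estimated value is 6000 nM, with an expected range of 1000 nM to 30000 nM.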

Compound 4, half-maximal inhibitory concentration: 15100 nM
Compound 4: the middle estimate sits 2.5-fold (0.40 log units) below what was measured; measured number inside the range.
By their numbers in this assay, from the lowest: compound 1; then compound 3; then compound 4.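

In this assay, within the data shown here, hydroxy in place of hydrogen on this aromatic carbon gives a 71-fold higher number from compound 3 to compound 4 (1.85 log units; beyond the scatter), the first direct reading of this change. The loss of potency therefore also occurs when the hydroxy of compound 3 is already present. Compound 4 also has a higher number than compound 2, which carries the new hydroxy but lacks the hydroxy of compound 3: the several entries of compound 2 in this assay, 4790 nM; 5750 nM (2 entries).

Still open, on these data alone, is whether an amine or a fluorine on this aromatic carbon would raise the number as far as hydroxy does.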